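Butyl for methoxy on the anilino ring of compound 1

A few compounds are considered here, and "the series" means these few. Any claim that something is new, unique, unknown or untested is made for them only; others in the source may bear on it.

Compound 1, `CCCSc1nc(Nc2ccc(OC)cc2)c2nc(Nc3ccccc3)sc2n1`, gives 30900 nM in a functional assay on HGC-27 cells (Homo sapiens) for antiproliferative activity, read by MTT assay, with a stated time of 72 h; on this read-out lower numbers stand for stronger inhibition and higher numbers for weaker inhibition.
Compound 2, `CCCSc1nc(NCc2ccco2)c2nc(Nc3ccccc3)sc2n1`, gives 28000 nM in this assay.
Compound 3, `CCCSc1nc(NC2CC2)c2nc(Nc3ccccc3)sc2n1`, gives 32400 nM in this assay.

Compound 1 stands second highest of the three numbers, and all three lie within the scatter of one another: a 1.1-fold lower number from compound 1 to compound 2 (0.04 log units; within the scatter), a 1.0-fold higher number from compound 1 to compound 3 (0.02 log units; within the scatter) and a 1.2-fold higher number from compound 2 to compound 3 (0.06 log units; within the scatter). Compound 4, `CCCCc1ccc(Nc2nc(SCCC)nc3sc(Nc4ccccc4)nc23)cc1`, differs from compound 1 by butyl in place of methoxy on an aromatic carbon. Within the data shown here, no measured step changes a substituent on that ring; the three steps exchange the whole group on the nitrogen and move nothing beyond the scatter. On that basis compound 4 is expected to show no step beyond the scatter, a 1.0-fold lower number from compound 1 to compound 4 (0.01 log units; within the scatter). Compound 4 is estimated at 30000 nM, within 12000 nM to 75000 nM.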

Compound 4, half-maximal inhibitory concentration: 13100 nM
For compound 4 the middle estimate is 2.3-fold (0.36 log units) above the measured one, within the range that was stated.
By their numbers in this assay, from the lowest: compound 4; then compounds 2, 1 and 3 (each within the scatter of the next).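

Butyl in place of methoxy gives the first step beyond the scatter at this position in this assay (a 2.4-fold lower number from compound 1 to compound 4 (0.37 log units; beyond the scatter)). The 4-butylphenyl group also separates from the other groups on that nitrogen (a 2.5-fold lower number from compound 3 to compound 4 (0.39 log units; beyond the scatter); a 2.1-fold lower number from compound 2 to compound 4 (0.33 log units; beyond the scatter)), so a substituent change on the ring moved the number when exchanging the three earlier groups had not. Nothing measured here accounts for this step. On these data alone, whether a shorter chain such as ethyl, a longer chain such as hexyl or an amine at the same place would follow butyl remains open.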